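The compounds below may be only part of what the source reports. "The series", "measured", "known", "first", "only" and "open" are said of these compounds alone.

Measured so far:
- compound 1 `CC(C)[C@H](NC(=O)CCN(C)C)c1cccc(F)c1N1CCN(C(=O)[C@@H]2CN(C(C)C)C[C@H]2c2ccc(Cl)cc2)CC1`, 5.3 nM in an assay on HEK293 cells for displacement of a labelled ligand from Melanocortin receptor 4 (Homo sapiens); a lower number here means a stronger inhibitor, a higher number a weaker inhibitor
- compound 2 `CC(C)[C@H](NC(=O)CCN(C)C)c1cccc(F)c1N1CCN(C(=O)[C@@H]2CN(C(C)C)C[C@H]2c2ccc(F)c(Cl)c2)CC1`, 260 nM in this assay

Among the measured compounds shown here, compound 2 stands highest of the two numbers, with a 49-fold higher number from compound 1 to compound 2 (1.69 log units; beyond the scatter) as the only step in hand. Compound 3 `Cc1cccc([C@@H]2CN(C(C)C)C[C@H]2C(=O)N2CCN(c3c(F)cccc3[C@@H](NC(=O)CCN(C)C)C(C)C)CC2)c1` differs from compound 2 by 3-methylphenyl in place of 3-chloro-4-fluorophenyl on a saturated ring carbon. For the measured compounds named here, no measured step bears directly on swapping a 3-chloro-4-fluorophenyl for a 3-methylphenyl; the one step known concerns a different pair of groups and was large. The direction is therefore uncertain, and a step of modest size, a 3.3-fold lower number from compound 2 to compound 3 (0.51 log units; beyond the scatter), is taken as the expectation. For compound 3 the estimate in this assay is 80 nM, within 15 nM to 400 nM.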

Compound 3, inhibition constant: 470 nM
Estimate against measurement, compound 3: 5.9-fold (0.77 log units) below; the measured number lies above the stated range.
By their numbers in this assay, from the lowest: compound 1; then compounds 2 and 3 (each within the scatter of the next).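

In this assay, 3-methylphenyl and 3-chloro-4-fluorophenyl on this saturated ring carbon cannot be told apart, with a 1.8-fold higher number from compound 2 to compound 3 (0.26 log units; within the scatter) as their step. Against the 4-chlorophenyl group, the 3-methylphenyl group gives an 89-fold higher number from compound 1 to compound 3 (1.95 log units; beyond the scatter) as its step, so compound 2 and compound 3 both stand well apart from compound 1, and two different replacements of 4-chlorophenyl have now given large steps. Nothing measured accounts for this.

Open, going by these compounds, is whether 4-methylphenyl, 4-bromophenyl or 3-chlorophenyl on this carbon would fall near compound 1 or near compound 2.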